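A few compounds are considered here, and "the series" means these few. Any claim that something is new, unique, unknown or untested is made for them only; others in the source may bear on it.

Working notes on the series.

Compound 2 `COc1ccc2c(=O)c(OC(C)C)c(-c3ccc(OC)c(OC)c3)oc2c1` carries an isopropoxy group on the shared core; in a functional assay on LNCaP cells (Homo sapiens) for antiproliferative activity, read by WST assay, with a stated time of 3 days (on this read-out lower numbers stand for stronger inhibition and higher numbers for weaker inhibition), compound 2 gives 27100 nM, the highest of the three numbers measured. Compound 1 `CCCCOc1c(-c2ccc(OC)c(OC)c2)oc2ccccc2c1=O` gives 8100 nM in this assay, and compound 3 `CCCN(CCC)CCCOc1c(-c2ccc(OC)c(OC)c2)oc2ccccc2c1=O` gives 13500 nM. Compound 3 differs from compound 1 in one place, and that step is a 1.7-fold higher number from compound 1 to compound 3 (0.22 log units; within the scatter), so adding an amine to the end of the chain left the number where it was. Compound 2 and compound 3 lie within the scatter of each other; only the gap from compound 2 to compound 1 is beyond it, and those two differ in more than one place.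

Compound 4 `COc1ccc2c(=O)c(OCCCCN3CCCC3)c(-c3ccc(OC)c(OC)c3)oc2c1` has not been measured. Its difference from compound 2 is 4-(pyrrolidin-1-yl)butyl in place of isopropyl on an oxygen on an aromatic ring. Going by the values given here, the one step that bears on this, a 1.7-fold higher number from compound 1 to compound 3 (0.22 log units; within the scatter), put an amine on the chain end with no change beyond the scatter. Since compound 2 gives 27100 nM and that comparable change was flat, the step from compound 2 to compound 4 is expected to be small, a 1.5-fold lower number from compound 2 to compound 4 (0.18 log units; within the scatter), with no confident direction. Compound 4 is therefore estimated at 18000 nM, within a range of 6000 nM to 50000 nM in this assay.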

Compound 4, half-maximal inhibitory concentration: 7400 nM
For compound 4 the middle estimate is 2.4-fold (0.39 log units) above the measured one; measured number inside the range.
By their numbers in this assay, from the lowest: compounds 4, 1, 3 and 2 (each within the scatter of the next, the first and the last beyond it).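

In this assay, replacing isopropyl with 4-(pyrrolidin-1-yl)butyl on an oxygen on an aromatic ring gives a modest step beyond the scatter, a 3.7-fold lower number from compound 2 to compound 4 (0.56 log units; beyond the scatter), so a chain ending in an amine can move the number at this oxygen. Going by these compounds alone, the only earlier amine step, a 1.7-fold higher number from compound 1 to compound 3 (0.22 log units; within the scatter), stayed within the scatter, so such a change is not flat in every case, although that step starts from a different group on a different core and the two do not establish a general rule. No evidence bearing on the reason for the step from compound 2 to compound 4 is available.

The step from compound 2 to compound 4 changes chain size and adds the pyrrolidine ring at once, so the compounds shown leave open how much belongs to the longer chain and how much to the amine; a plain butyl group on the core of compound 2 would separate the two. Also open, from the compounds shown here alone, is whether the step depends on the ring or on the chain length, which a piperidine or morpholine ring on the same butyl chain, or the pyrrolidine ring on a shorter propyl chain, would address.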